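The source may hold more compounds than are shown below. What is called first, only, known or untested is meant among the compounds shown, and "the series" means these compounds.

Compound 3 `CSc1ccc(OC(C)(C)C2OCC(C/C=C\CCC(=O)O)C(c3cccnc3)O2)c([N+](=O)[O-])c1` stands second highest of the three numbers in an assay for inhibition of prostacyclin synthase (Homo sapiens), using microsomes (a higher number here means a weaker inhibitor, a lower number a stronger inhibitor), where compound 3 gives 5000 nM; compound 1 `O=C(O)CC/C=C\CC1COC(c2ccc(Cl)cc2Cl)OC1c1cccnc1` gives 2500 nM, a gap within the scatter, while compound 2 `CC(C)(Oc1ccccc1)C1OCC(C/C=C\CCC(=O)O)C(c2cccnc2)O1` gives 75000 nM. Compound 4 `COc1ccccc1OC(C)(C)C1OCC(C/C=C\CCC(=O)O)C(c2cccnc2)O1` differs from compound 3 by a group of 8 heavy atoms (7 carbon, 1 oxygen; one six-membered aromatic ring of carbon only) in place of a group of 11 heavy atoms (7 carbon, 1 nitrogen, 2 oxygen, 1 sulfur; one six-membered aromatic ring of carbon only), on an oxygen on a saturated carbon. The measured step that bears on this position is a 15-fold lower number from compound 2 to compound 3 (1.18 log units; beyond the scatter); the other step, a 30-fold higher number from compound 1 to compound 2 (1.48 log units; beyond the scatter), changed a different part of the core and bears less here. Compound 4 carries a smaller group on that oxygen than compound 3 but a larger one than compound 2, so a number between those two is expected, a 4.0-fold higher number from compound 3 to compound 4 (0.60 log units; beyond the scatter). The estimate for compound 4 in this assay is 20000 nM, with a range from 5000 nM to 80000 nM.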

Compound 4, half-maximal inhibitory concentration: 51000 nM
Estimate against measurement, compound 4: 2.6-fold (0.41 log units) below, within the range that was stated.
By their numbers in this assay, from the lowest: compounds 1 and 3 (each within the scatter of the next); then compounds 4 and 2 (each within the scatter of the next).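

In this assay the step of a 10-fold higher number from compound 3 to compound 4 (1.01 log units; beyond the scatter) shows that 2-methoxyphenyl on this oxygen does not keep the gain seen with the group in compound 3. The step of a 1.5-fold lower number from compound 2 to compound 4 (0.17 log units; within the scatter) comes with methoxy in place of hydrogen on an aromatic carbon and leaves compound 4 within the scatter of compound 2, so methoxy alone does not reproduce that gain. No evidence on the cause is available. Which substituent on the aromatic ring of compound 3 carries the gain remains open. So does the outcome with an amine or a carboxylic acid in place of methoxy on that ring.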